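Replacing 4-methylphenyl with 3-chlorophenyl in a flat series

A few compounds are considered here, and "the series" means these few. Any claim that something is new, unique, unknown or untested is made for them only; others in the source may bear on it.

Of the compounds shown here, three built on one shared core have been tested so far. In a functional assay on K562 cells (Homo sapiens) for cytotoxicity, read by ELISA, with a stated time of 4 days (on this read-out higher numbers stand for weaker inhibition and lower numbers for stronger inhibition), compound 1 `Cc1ccc(-c2cc(-c3ccoc3)cc(-c3ccc(Cl)s3)n2)o1` gives 12700 nM, compound 2 `Cc1ccccc1-c1cc(-c2ccoc2)cc(-c2ccc(Cl)s2)n1` gives 12300 nM and compound 3 `Cc1ccc(-c2cc(-c3ccoc3)cc(-c3ccc(Cl)s3)n2)cc1` gives 17900 nM. Compound 3 therefore stands level with the other two, since a 1.4-fold higher number from compound 1 to compound 3 (0.15 log units; within the scatter) and a 1.5-fold higher number from compound 2 to compound 3 (0.16 log units; within the scatter) both stay within the ordinary scatter of repeated measurements.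

Compound 4 `Clc1cccc(-c2cc(-c3ccoc3)cc(-c3ccc(Cl)s3)n2)c1` differs from compound 3 in one place, with 3-chlorophenyl in place of 4-methylphenyl on an aromatic carbon. The steps just given exchange the group at this same place, and so does a 1.0-fold lower number from compound 1 to compound 2 (0.01 log units; within the scatter), which is also within the scatter. For the measured compounds named here, these three steps are small, yet none of the measured compounds carries 3-chlorophenyl, so they offer only indirect guidance. Going by the step to compound 3 from compound 2, a 1.5-fold higher number from compound 2 to compound 3 (0.16 log units; within the scatter), no change beyond the scatter is expected in this assay. The expected step is a 1.3-fold lower number from compound 3 to compound 4 (0.11 log units; within the scatter), which would also lie within the scatter. For compound 4 the estimated value is 14000 nM, with an expected range from 7000 nM to 28000 nM.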

Compound 4, half-maximal inhibitory concentration: 22100 nM
Compound 4: the middle estimate sits 1.6-fold (0.20 log units) below what was measured, and the stated range covers the measured number.
By their numbers in this assay, from the lowest: compounds 2, 1, 3 and 4 (each within the scatter of the next).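

The place next to the ring nitrogen now holds a chlorine-bearing ring for the first time among these compounds, and in this assay compound 4 stands level with all three others (a 1.2-fold higher number from compound 3 to compound 4 (0.09 log units; within the scatter); a 1.8-fold higher number from compound 2 to compound 4 (0.25 log units; within the scatter); a 1.7-fold higher number from compound 1 to compound 4 (0.24 log units; within the scatter)). All three steps lie within the scatter, so 5-methylfuran-2-yl, 2-methylphenyl, 4-methylphenyl and 3-chlorophenyl cannot be told apart here, and a chlorine on the phenyl ring gives no separation from a methyl on it. No measurement is at hand that could explain this flat result.

The compounds shown leave open whether a ring carrying an amine or a carboxylic acid at this place, or a small alkyl chain in place of the ring, would stand apart from these four. On these data alone, all four compounds also share the furan-3-yl and 5-chlorothiophen-2-yl groups, and what those two groups contribute to the cytotoxic effect remains unknown.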